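Swapping a Cyclopentyl Ring for a Halogenated Benzene Ring

The source may report more compounds than this note shows. Statements on the series, on what has been measured and on what is new or still open speak of the compounds shown alone.

Of the compounds shown here, three sharing one core have been measured in an ADME assay on A549 cells (Homo sapiens) for cytotoxicity, read by resazurin assay, with a stated time of 48 h; a higher number here means that more compound is tolerated, a lower number that less compound is tolerated. Compound 1 `CCCCCCCCC(C)Nc1ccc(NC(=O)c2cc(Cl)ccc2O)c(Cl)c1` gives 21900 nM. Compound 2 `O=C(Nc1ccc(NCC2CCCC2)cc1Cl)c1cc(Cl)ccc1O` gives 21500 nM, and compound 3 `O=C(Nc1ccc(N(CC2CC2)CC2CC2)cc1Cl)c1cc(Cl)ccc1O` gives 12800 nM. Compound 2 thus stands second highest of the three numbers; compound 1 sits nearest to it, within the scatter, and compound 3 furthest, also within the scatter, so these three cannot be ranked against one another on the numbers at hand.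

The step from compound 2 to compound 4 `O=C(Nc1ccc(NCc2cc(F)cc(Cl)c2)cc1Cl)c1cc(Cl)ccc1O` alters the group attached through the saturated chain carbon bound to a nitrogen on an aromatic ring: 3-chloro-5-fluorophenyl in place of cyclopentyl on a saturated chain carbon bound to a nitrogen on an aromatic ring.

Among the measured compounds shown here, only one measured step touches the same part of the molecule. a 1.7-fold lower number from compound 2 to compound 3 (0.23 log units; within the scatter). That step exchanged one saturated ring group for a different saturated arrangement and left the number essentially where it was. The move to compound 4 instead brings in an aromatic ring carrying a fluorine and a chlorine, and nothing measured here shows how such a ring behaves at this place. For the measured compounds named here, with the one related step lying within the scatter, a number close to that of compound 2 is expected, with a wider range to cover the untested ring. The estimated step is a 1.2-fold lower number from compound 2 to compound 4 (0.08 log units; within the scatter). Compound 4 is expected to give about 18000 nM in this assay, within a range from 7000 nM to 45000 nM.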

Compound 4, half-maximal cytotoxic concentration: 11100 nM
Estimate against measurement, compound 4: 1.6-fold (0.21 log units) above, within the range that was stated.
By their numbers in this assay, from the lowest: compounds 4, 3, 2 and 1 (each within the scatter of the next).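

In this assay, putting 3-chloro-5-fluorophenyl in place of cyclopentyl on a saturated chain carbon bound to a nitrogen on an aromatic ring gives a 1.9-fold lower number from compound 2 to compound 4 (0.29 log units; within the scatter) and stays inside the normal spread of repeated measurements. The earlier step at this part of the molecule involved only saturated groups, whereas this one shows that an aromatic ring carrying a fluorine and a chlorine can stand here with no change in tolerated concentration that can be told apart from that spread. Nothing available explains the size of this step or links it to any property of the two groups.

Among the compounds shown here, with only this one aromatic ring in view, the separate contributions of the chlorine and the fluorine remain unknown, and so does the reading for a plain phenyl ring or a ring with only one of these halogens. It is also open how this place would respond to a pyridine ring, or to a benzene ring carrying an amine or a carboxylic acid, as the compounds shown contain none of these groups.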